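From fluoro to chloro with a methyl on the amine

This account rests on a few compounds, and the source may have more. Where it says the series, first, only, none or still open, it means among the compounds named here.

Compound 2 (`CNC1=NS(=O)(=O)c2cc(F)ccc2N1`) gives > 300 uM in a functional assay (aorta) with Rattus norvegicus as the target (on this read-out higher numbers stand for an effect only at larger amounts of compound and lower numbers for an effect already at smaller amounts), and this is a limit of the assay, not a number. Compound 4 (`CNC1=NS(=O)(=O)c2cc(Cl)ccc2N1`) keeps the same methyl on the amine nitrogen and differs in one place, with chloro in place of fluoro on an aromatic carbon. For the measured compounds named here, no measured step covers this swap on its own. Compound 3 (`CC(C)C(C)NC1=NS(=O)(=O)c2cc(F)ccc2N1`) gives 26.4 uM in this assay. Going by the values given here, the one measured step is large, an at least 11-fold lower number from compound 2 to compound 3 (1.05 log units; beyond the scatter), and it comes with 1,2-dimethylpropyl in place of methyl on an amine nitrogen, a change that compound 4 does not make. Compound 1 (`CC(C)NC1=NS(=O)(=O)c2cc(Cl)ccc2N1`) carries chloro together with a larger amine group than methyl and gives 36.3 uM in this assay. With the methyl kept, no step beyond the scatter is expected in this assay, and a second limit would be no surprise. The estimated change is an at least 1.2-fold lower number from compound 2 to compound 4 (0.07 log units; that floor lies within the scatter). Compound 4 is expected at 250 uM, with an estimated range of 90 uM to 600 uM.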

Compound 4, concentration for half-maximal effect: 142 uM
Beside the measured number, compound 4's estimate is 1.8-fold (0.25 log units) above it, and the stated range covers the measured number.
By their numbers in this assay, from the lowest: compounds 3 and 1 (each within the scatter of the next); then compound 4. At a limit, above all of these: compound 2.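

With the methyl on the amine nitrogen kept, chloro in place of fluoro on the aromatic carbon moves the read-out in this assay on its own, with an at least 2.1-fold lower number from compound 2 to compound 4 (0.32 log units; beyond the scatter). Only a floor for this step can be read, because compound 2 gives a limit and not a number: the limit of > 300 uM in this assay, at which 1 of the 4 values shown sits. With chloro kept, methyl in place of isopropyl on the amine nitrogen gives a 3.9-fold higher number from compound 1 to compound 4 (0.59 log units; beyond the scatter), so the amine group matters with chloro as well as with fluoro.

As far as these compounds go, it remains open whether chloro in place of fluoro shifts the number by the same amount when the amine nitrogen carries isopropyl or 1,2-dimethylpropyl. Also open, from the compounds shown here alone, is how bromo or a nitrile on that aromatic carbon, or a longer chain such as butyl on the amine nitrogen, would read in this assay.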